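Triazole nitrogen substituent and cellular potency: compound 4

The compounds below may be only part of what the source reports. "The series", "measured", "known", "first", "only" and "open" are said of these compounds alone.

Measured so far:
- compound 1 `CCCn1nc(C(=O)N[C@H]2COc3ccccc3N(C)C2=S)nc1Cc1ccccc1` gives 288 nM in a functional assay on HT-29 cells (Homo sapiens) for inhibition, read by luminescence and CellTiter-Glo, with a stated time of 24 h; on this read-out higher numbers stand for an effect only at larger amounts of compound and lower numbers for an effect already at smaller amounts
- compound 2 `CN1C(=S)[C@@H](NC(=O)c2nc(Cc3ccccc3)n(CCCCC#N)n2)COc2ccccc21` gives 2680 nM in this assay
- compound 3 `CN1C(=S)[C@@H](NC(=O)c2nc(Cc3ccccc3)n(C3CCCCCC3)n2)COc2ccccc21` gives 5530 nM in this assay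

Compound 1 has the lowest of the three numbers; compound 2 is nearest and compound 3 furthest, both steps beyond the scatter.

Compound 4 `CN1C(=S)[C@@H](NC(=O)c2nc(Cc3ccccc3)n(C3CCN(C(=O)OC(C)(C)C)C3)n2)COc2ccccc21` is not yet measured. It differs from compound 1 in that (a group of 12 heavy atoms (9 carbon, 1 nitrogen, 2 oxygen; one five-membered non-aromatic ring with 1 hetero atom) in place of a group of 3 heavy atoms (3 carbon; no ring), on an aromatic nitrogen).

Two measured steps start from compound 1 and also enlarge the group on the aromatic nitrogen: a 9.3-fold higher number from compound 1 to compound 2 (0.97 log units; beyond the scatter) and a 19-fold higher number from compound 1 to compound 3 (1.28 log units; beyond the scatter). The third, a 2.1-fold higher number from compound 2 to compound 3 (0.31 log units; beyond the scatter), adds that the ring-bearing cycloheptyl sits at the higher end. Every enlargement of the propyl so far has raised the number, and the ring-bearing one raised it most. The entering group of compound 4 is larger than propyl and also carries a ring, so a clearly higher number is expected, of roughly the size seen with cycloheptyl; the expected step is a 14-fold higher number from compound 1 to compound 4 (1.14 log units; beyond the scatter).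

For compound 4 the estimate in this assay is 4000 nM, within 1200 nM to 13000 nM.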

Compound 4, half-maximal effective concentration: > 10000 nM
Compound 4: only a limit was reported; the forecaster's own chance of this, stated with the estimate: 15%; middle value at least 2.5-fold (0.39 log units) away from the limit.
By their numbers in this assay, from the lowest: compound 1; then compound 2; then compound 3. At a limit, above all of these: compound 4.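

In this assay the reading for compound 4 is a limit and not a number: the limit of > 10000 nM in this assay, at which 1 of the 4 values shown sits. On the aromatic nitrogen, the group with a five-membered non-aromatic ring and 2 hydrogen-bond acceptors continues the rise seen with every replacement of propyl among the compounds shown, with no compound going against it: the result is an at least 34-fold higher number from compound 1 to compound 4 (1.54 log units; beyond the scatter), and it also stands clear of the nitrile-bearing chain, with an at least 3.7-fold higher number from compound 2 to compound 4 (0.57 log units; beyond the scatter). The comparison of the two ring-bearing groups stays unresolved, since the result of an at least 1.8-fold higher number from compound 3 to compound 4 (0.25 log units; that floor lies within the scatter) gives a floor only, so hetero atoms and hydrogen-bond acceptors in the entering group did not bring the number back towards that of compound 1, but compound 4 cannot be placed relative to compound 3.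

Open, going by these compounds, is how a group smaller than propyl, such as methyl or ethyl, or an unbranched butyl chain would read at this position. Also open, on these data alone, is whether the same five-membered ring carrying a free amine in place of its substituted nitrogen would read differently from compound 4.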